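A Chloro-to-Methoxy Swap in a Macrophage Toxicity Test

This account rests on a few compounds, and the source may have more. Where it says the series, first, only, none or still open, it means among the compounds named here.

Measured so far in a toxicity assay on cells (Macrophage, Homo sapiens) for inhibition, read by MTT assay; on this read-out higher numbers stand for weaker inhibition and lower numbers for stronger inhibition:
- compound 1 (`CN(C)CCNc1nc(-c2ccc(Cl)cc2)nc2ccccc12`) gives 60000 nM
- compound 2 (`NCCNc1nc(-c2ccc(Cl)cc2)nc2ccccc12`) gives 15000 nM

Compound 1 holds the higher of these two numbers, so of this pair it inhibits more weakly. Compound 3 (`COc1ccc(-c2nc(NCCN(C)C)c3ccccc3n2)cc1`) has methoxy in place of chloro on an aromatic carbon, which turns 4-chlorophenyl into 4-methoxyphenyl. Within the data shown here, no measured step touches that group. Among the measured compounds shown here, the only step available (a 4.0-fold lower number from compound 1 to compound 2 (0.60 log units; beyond the scatter)) puts amino in place of dimethylamino and leaves the 4-chlorophenyl unchanged. It is modest in size, and it shows how far one small change can move the number, but it gives no direction for this swap. In this assay a step no larger than that one is therefore expected, most likely none beyond the scatter. The estimated step is small (a 1.2-fold lower number from compound 1 to compound 3 (0.08 log units; within the scatter)). For compound 3 the estimated value is 50000 nM (expected range 20000 nM to 120000 nM).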

Compound 3, half-maximal inhibitory concentration: 57000 nM
For compound 3 the middle estimate is 1.1-fold (0.06 log units) below the measured one; low and high end bracket the measured number.
By their numbers in this assay, from the lowest: compound 2; then compounds 3 and 1 (each within the scatter of the next).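

In this assay, replacing 4-chlorophenyl with 4-methoxyphenyl gives a 1.1-fold lower number from compound 1 to compound 3 (0.02 log units; within the scatter) and so the two compounds cannot be told apart. Among these compounds, this is the first measured change on the aromatic ring, since the earlier step of a 4.0-fold lower number from compound 1 to compound 2 (0.60 log units; beyond the scatter) lay at the amine end of the chain and went beyond the scatter. Among these three compounds, then, the chain change shifts the number while the chloro-to-methoxy swap does not, and nothing measured here offers an explanation for either result.

On these data alone, whether other groups at this place, such as fluoro, hydroxy or trifluoromethyl, would also stay within the scatter remains open. So does whether methoxy would behave the same way on compound 2, which carries amino in place of dimethylamino.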